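Pyridin-4-yl for phenyl on the pyridyl ether core

The source may report more compounds than this note shows. Statements on the series, on what has been measured and on what is new or still open speak of the compounds shown alone.

Measured compounds:
Compound 1, `C#Cc1cncc(O[C@@H]2CCNC2)c1`, gives 62 nM.
Compound 2, `c1ccc(-c2cncc(O[C@@H]3CCNC3)c2)cc1`, gives 1820 nM.

Both were measured in an assay on a protein complex for binding affinity to Neuronal acetylcholine receptor; alpha4/beta2 (Rattus norvegicus); a lower number here means a stronger inhibitor, a higher number a weaker inhibitor. Going by the values given here, compound 2 stands as the highest of the two numbers; its nearest neighbour is compound 1, and the move a 29-fold higher number from compound 1 to compound 2 (1.47 log units; beyond the scatter) is the only step so far, and it is large.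

Compound 3, `c1cc(-c2cncc(O[C@@H]3CCNC3)c2)ccn1`, differs from compound 2 by pyridin-4-yl in place of phenyl on an aromatic carbon. Among the compounds with values here, no measured step speaks directly to swapping one six-membered aromatic ring for another of the same size; the one known step concerns replacing ethynyl by phenyl, and it shows that the group at this position matters strongly, but it does not tell which way a change within the six-membered ring would go. On that basis only a modest move is expected, if any, and the direction is uncertain. Compound 3 is therefore expected to come out close to compound 2, with an estimated step of a 1.5-fold lower number from compound 2 to compound 3 (0.18 log units; within the scatter). The estimate for compound 3 in this assay is 1200 nM, within a range from 300 nM to 5000 nM.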

Compound 3, half-maximal inhibitory concentration: 571 nM
Compound 3: the middle estimate sits 2.1-fold (0.32 log units) above what was measured; the range from low to high includes it.
By their numbers in this assay, from the lowest: compound 1; then compound 3; then compound 2.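

Within the shared core, this position responds to a single atom change in the attached six-membered aromatic ring, not only to the replacement of ethynyl by a ring. In this assay, pyridin-4-yl in place of phenyl gives a 3.2-fold lower number from compound 2 to compound 3 (0.50 log units; beyond the scatter), a step beyond the scatter, so the two rings are not interchangeable here even though each has the same count of heavy atoms. Pyridin-4-yl recovers only part of the loss seen with phenyl, since a 9.2-fold higher number from compound 1 to compound 3 (0.96 log units; beyond the scatter) remains, compared with a 29-fold higher number from compound 1 to compound 2 (1.47 log units; beyond the scatter), and nothing available here accounts for the difference between the two rings.

These three compounds leave open whether the gain depends on where the nitrogen sits in the ring, which a pyridin-3-yl or pyridin-2-yl group at the same place would test, and whether an added amine or methoxy group on the pyridin-4-yl ring would move the number further. They also leave open whether any ring at this place can match ethynyl, or whether a nitrile or a propynyl group would come closer to compound 1.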